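Swapping a Nitrile for a Methyl on the Phenyl Ring

This account rests on a few compounds, and the source may have more. Where it says the series, first, only, none or still open, it means among the compounds named here.

Compound 1, `Cc1nnc(SCC(=O)N/N=c2/scc(-c3ccc(C#N)cc3)n2-c2ccccc2)s1`: in an ADME assay on NIH3T3 cells (Mus musculus) for cytotoxicity, read by MTT assay, with a stated time of 24 h (on this read-out lower numbers stand for stronger inhibition and higher numbers for weaker inhibition), compound 1 sits at the limit < 3.9 ug/mL, which is a limit of the assay and not a number.
Compound 2, `Cn1cnnc1SCC(=O)N/N=c1/scc(-c2ccc(C#N)cc2)n1-c1ccccc1`: compound 2 gives 153 ug/mL.
Compound 3, `Cn1nnnc1SCC(=O)N/N=c1/scc(-c2ccc(C#N)cc2)n1-c1ccccc1`: compound 3 gives 213 ug/mL.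

Of the two numbers in this assay, compound 2 has the lower one; compound 3 is the nearest, and the step of a 1.4-fold higher number from compound 2 to compound 3 (0.14 log units; within the scatter) lies within the scatter. Both differ from compound 1 by large steps, an at least 39-fold higher number from compound 1 to compound 2 (1.59 log units; beyond the scatter) and an at least 54-fold higher number from compound 1 to compound 3 (1.73 log units; beyond the scatter), with compound 1 sitting at the limit of < 3.9 ug/mL in this assay, at which 1 of the 3 values shown sits.

Compound 4, `Cc1ccc(-c2cs/c(=N/NC(=O)CSc3nncn3C)n2-c2ccccc2)cc1`, is not yet measured. It differs from compound 2 by methyl in place of cyano on an aromatic carbon. For the measured compounds named here, all three measured steps concern the ring on the sulfur, not this phenyl substituent, so no measured step bears on this change, and no step beyond the scatter is expected in this assay. Compound 4 is therefore estimated at 150 ug/mL, with a range from 50 ug/mL to 450 ug/mL. This estimate means a step of a 1.0-fold lower number from compound 2 to compound 4 (0.01 log units; within the scatter), expected to stay within the scatter.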

Compound 4, half-maximal inhibitory concentration: 130 ug/mL
The estimate for compound 4 lay 1.2-fold (0.06 log units) above the measured number; measured number inside the range.
By their numbers in this assay, from the lowest: compounds 4, 2 and 3 (each within the scatter of the next). At a limit, below all of these: compound 1.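

For the compounds shown here, compounds 1, 2 and 3 differ only in the ring on the sulfur, so compound 4 gives the first reading for a change on the aromatic carbon para to a large group. In this assay, exchanging cyano for methyl there removes a triple bond and a hydrogen-bond acceptor, yet the result is a 1.2-fold lower number from compound 2 to compound 4 (0.07 log units; within the scatter), so this read-out does not separate these two groups on the shared core. Nothing measured here explains this result.

From the compounds shown here alone, whether other groups at this place, such as an amine or a carboxylic acid, would also leave the number within the scatter stays open. Also open, going by these compounds, is how this exchange would read with the 5-methyl-1,3,4-thiadiazol-2-yl group on the sulfur: compound 1, which carries that group, gives < 3.9 ug/mL, a limit and not a number.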